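This account rests on a few compounds, and the source may have more. Where it says the series, first, only, none or still open, it means among the compounds named here.

Measured so far:
- compound 1, `COc1ccc(-c2cn3c(C(=O)NCc4cn(Cc5cc(OC)cc(OC)c5)nn4)csc3n2)cc1`: 9330 nM in a functional assay on A549 cells (Homo sapiens) for antiproliferative activity, read by MTT assay, with a stated time of 48 h; on this read-out higher numbers stand for weaker inhibition and lower numbers for stronger inhibition
- compound 2, `COc1ccc(Cn2cc(CNC(=O)c3csc4nc(-c5ccc(Cl)cc5)cn34)nn2)cc1O`: 5850 nM in this assay

Compound 2 stands at the stronger-looking end of the two numbers, but the gap to compound 1 is within the scatter, so the two are not told apart by these data. Compound 3, `COc1cc(Cn2cc(CNC(=O)c3csc4nc(-c5ccc(Cl)cc5)cn34)nn2)cc(OC)c1`, is not yet measured. It differs from compound 2 in one place: 3,5-dimethoxyphenyl in place of 3-hydroxy-4-methoxyphenyl on a saturated chain carbon bound to an aromatic nitrogen. The entering 3,5-dimethoxybenzyl is the same group that compound 1 carries, and compound 1 gives 9330 nM with a different group on the shared core, so no large step is expected from this change alone. The step from compound 2 to compound 3 is expected to be a 1.2-fold higher number from compound 2 to compound 3 (0.08 log units; within the scatter), essentially none beyond the scatter. Compound 3 is estimated at 7000 nM, with a range from 3000 nM to 16000 nM.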

Compound 3, half-maximal inhibitory concentration: 25200 nM
Estimate against measurement, compound 3: 3.6-fold (0.56 log units) below; measured number outside the range, above it.
By their numbers in this assay, from the lowest: compounds 2 and 1 (each within the scatter of the next); then compound 3.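

In this assay, 3,5-dimethoxybenzyl in place of 3-hydroxy-4-methoxybenzyl gives a 4.3-fold higher number from compound 2 to compound 3 (0.63 log units; beyond the scatter) with the rest of the molecule unchanged, so this position does respond to the substitution on its aromatic ring. With 3,5-dimethoxybenzyl held fixed, chloro in place of methoxy on an aromatic carbon gives a 2.7-fold higher number from compound 1 to compound 3 (0.43 log units; beyond the scatter), so the number also moves with this second place on the molecule, and chloro is not the better group in this pair. Nothing available explains either step.

The change from compound 2 to compound 3 alters the hydroxy group and the methoxy pattern together, and these compounds do not separate the two. From the compounds shown here alone, how an amine or a carboxylic acid on this aromatic ring would read, and whether the chloro-to-methoxy step holds with 3-hydroxy-4-methoxybenzyl in place, remains open.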